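Swapping cyano for carbamoyl: an estimate for compound 3

A few compounds are considered here, and "the series" means these few. Any claim that something is new, unique, unknown or untested is made for them only; others in the source may bear on it.

Measured in an ADME assay on L6 cells (Rattus norvegicus) for cytotoxicity, read by resazurin assay, with a stated time of 72 h; on this read-out higher numbers stand for weaker inhibition and lower numbers for stronger inhibition:
- Compound 1 `OC(c1ccc(Br)cc1)(c1ccc(C(F)(F)F)cc1)c1cccnc1`: 54700 nM
- Compound 2 `N#Cc1ccc(C(O)(c2ccc(C(F)(F)F)cc2)c2cccnc2)cc1`: 76500 nM

Only these two compounds have been measured so far, and compound 2 stands level with compound 1 once the normal scatter of repeat measurements is taken into account. The next compound, compound 3 `NC(=O)c1ccc(C(O)(c2ccc(C(F)(F)F)cc2)c2cccnc2)cc1`, keeps the core of compound 2 but carries carbamoyl in place of cyano on an aromatic carbon, para to a large group: carbamoyl in place of cyano on an aromatic carbon. Within the data shown here, one measured step bears on this, made at the same place, with cyano in place of bromo: a 1.4-fold higher number from compound 1 to compound 2 (0.15 log units; within the scatter). Among the measured compounds shown here, no measured compound yet carries carbamoyl, so this small step is the only guide, and the range has to stay wide. The expected step is therefore no larger than the scatter: a 1.0-fold higher number from compound 2 to compound 3 (0.02 log units; within the scatter). Compound 3 is estimated at 80000 nM, with an expected range from 35000 nM to 180000 nM.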

Compound 3, half-maximal inhibitory concentration: > 100000 nM
Compound 3 ended at the assay's limit (the forecaster's own chance of this, stated with the estimate: 15%); at least 1.2-fold (0.09 log units) between middle value and limit.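

In this assay, compound 3 gives no number, only a limit of the assay: the limit of > 100000 nM in this assay, at which 1 of the 3 values shown sits. Unlike cyano, carbamoyl carries a hydrogen-bond donor, and this position now gives its first result at the limit, so the steps can be read only as floors: an at least 1.3-fold higher number from compound 2 to compound 3 (0.11 log units; that floor lies within the scatter), and an at least 1.8-fold higher number from compound 1 to compound 3 (0.26 log units; that floor lies within the scatter). Both floors lie within the scatter, so this result does not yet separate compound 3 from compound 1 or compound 2, although its true value could lie further away.

From the compounds shown here alone, how far past the limit compound 3 lies remains unknown, and one carbamoyl cannot show whether the hydrogen-bond donor itself matters. An amine or a carboxylic acid at this same place would test whether other groups also reach the limit.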